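Amide Swap and Distribution Volume in a Rat Study

This account rests on a few compounds, and the source may have more. Where it says the series, first, only, none or still open, it means among the compounds named here.

Compound 1 `COc1cc(C(=O)N2CCCC2)ccc1-c1ccnc2[nH]c(C3CCOCC3)cc12`: 0.8 L/kg
Compound 2 `CC(C)n1cc(-c2ccnc3[nH]c(C4CCN(CC(=O)N5CCCC5)CC4)cc23)ccc1=O`: 3.9 L/kg
Compound 3 `COc1cc(F)ccc1-c1ccnc2[nH]c([C@H]3CC[C@H](NC(C)=O)CC3)cc12`: 2.5 L/kg

Three compounds built on a shared core were studied in an ADME assay (Rattus norvegicus, strain Han-wistar) for pharmacokinetics, at a dose of 1.5 umol/kg by the intravenous route; a lower number here means that more of the compound stays in the plasma, a higher number that more of the compound sits outside the plasma. Compound 1 gives 0.8 L/kg, compound 2 gives 3.9 L/kg and compound 3 gives 2.5 L/kg. The number for compound 2 is the largest of the three, but its gap to compound 3 is within the usual scatter, so these two cannot be told apart; the gap to compound 1, by contrast, lies beyond the scatter, so compound 2 clearly sits outside the plasma to a greater extent than compound 1.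

Compound 4 `CNC(=O)CN1CCC(c2cc3c(-c4ccc(=O)n(C(C)C)c4)ccnc3[nH]2)CC1` has not yet been measured in this assay. It differs from compound 2 in one place: methylamino in place of pyrrolidin-1-yl on a carbonyl carbon. Among the compounds with values here, no measured pair in this set shows the same change, so its effect on this assay is unknown from the data. The expected step is a 1.3-fold lower number from compound 2 to compound 4 (0.11 log units; within the scatter), which is judged to stay within the scatter. Compound 4 is estimated to give 3 L/kg, with a range from 1.5 L/kg to 6 L/kg.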

Compound 4, volume of distribution: 2.6 L/kg
Beside the measured number, compound 4's estimate is 1.2-fold (0.06 log units) above it; measured number inside the range.
By their numbers in this assay, from the lowest: compound 1; then compounds 3, 4 and 2 (each within the scatter of the next).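

In this assay the change from pyrrolidin-1-yl to methylamino on a carbonyl carbon, with a saturated chain carbon as that carbon's other neighbour, gives a 1.5-fold lower number from compound 2 to compound 4 (0.18 log units; within the scatter) and so leaves the two compounds indistinguishable. Within the data shown here, this is the first pair in the set that differs in one place, and it shows that the five-membered ring of compound 2 can give way to an open methylamino group, bringing the amide hydrogen as a hydrogen-bond donor, with no readable shift in volume of distribution at this position. No measurement available here bears on why the two compounds read alike.

The compounds shown leave open whether a larger replacement on the same carbonyl carbon, such as a morpholine or a longer chain amine, or a carboxylic acid in place of the whole amide, would move the number beyond the scatter. They also leave open whether the same swap would read the same way on compound 1, which carries a (pyrrolidin-1-yl)carbonyl group of its own on a different part of the molecule.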